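The source may hold more compounds than are shown below. What is called first, only, known or untested is meant among the compounds shown, and "the series" means these compounds.

Among the compounds with values here, compound 2 `CCc1ccc2nc(C(=O)Nc3c(F)cc(-c4cccc(F)c4)cc3F)c(C)c(O)c2c1` stands highest of the two numbers so far in a functional assay on A-375 cells (Homo sapiens) for antiproliferative activity, read by MTT assay, with a stated time of 24 h, tested at 33.33 ug/mL (a lower number here means a weaker effect, a higher number a stronger effect of the compound at the concentration tested), where compound 2 gives 28.4%. Within the data shown here, its only neighbour is compound 1 `Cc1ccc2nc(C(=O)Nc3c(F)cc(-c4cccc(F)c4)cc3F)c(C)c(O)c2c1`, which in this assay gives 26.5%, and the step between them is a number 1.9 percentage points higher from compound 1 to compound 2 (within the scatter), so the two cannot be told apart. Compound 3 `Cc1c(C(=O)Nc2c(F)cc(-c3cccc(F)c3)cc2F)nc2ccc(F)cc2c1O` is yet to be measured in this assay. It differs from compound 2 by fluoro in place of ethyl on an aromatic carbon. Among the measured compounds shown here, the one measured step that touches this part of the shared core, a number 1.9 percentage points higher from compound 1 to compound 2 (within the scatter), changes a saturated chain carbon and brings in no fluorine, so it says only that this position has so far tolerated small changes without a shift beyond the scatter. With nothing else to go on, no step beyond the scatter is expected. Compound 3 is therefore estimated to give 27% in this assay, within a range of 14% to 40%, an expected step of a number 1.4 percentage points lower from compound 2 to compound 3 (within the scatter).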

Compound 3, a percentage reported as inhibition, at one concentration (the size of the read-out at that concentration, not a potency): 28.8%
Compound 3: the middle estimate sits 1.8 percentage points below what was measured; the measured number falls inside the stated range.
By their numbers in this assay, from the lowest: compounds 1, 2 and 3 (each within the scatter of the next).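

In this assay, fluoro in place of ethyl on this aromatic carbon gives a number 0.4 percentage points higher from compound 2 to compound 3 (within the scatter) and fluoro in place of methyl gives a number 2.3 percentage points higher from compound 1 to compound 3 (within the scatter) in the same measurement. The earlier pair compared only two carbon chains, whereas this result shows that a single fluorine atom can take the place of either chain with no difference that can be read in this assay. No measurement at hand explains why these three groups read alike.

From the compounds shown here alone, what an amine, a carboxylic acid or a longer chain such as butyl would do at this position remains open. Going by these compounds, each compound is also described by a single concentration, so whether the three would separate at other concentrations also remains unknown.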